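The compounds below may be only part of what the source reports. "The series", "measured", "known", "first", "only" and "open" are said of these compounds alone.

Compound 1 `COCCOCn1c(Br)c(C#N)c2c(N)ncnc21` gives > 100000 nM in a functional assay on KB cells (Homo sapiens) for inhibition (a lower number here means a stronger inhibitor, a higher number a weaker inhibitor), which is a limit of the assay rather than a number.
Compound 3 `CCOCn1c(Br)c(C#N)c2c(N)ncnc21` gives > 100000 nM in this assay, again a limit.
Compound 2 `CCOCn1c(N)c(C(=N)S)c2c(N)ncnc21` gives > 320000 nM in this assay, also a limit.

Compound 1 therefore stands at a limit, and so do the other two measured compounds: none of the three returns a number, and no order can be drawn among them. Among the compounds with values here, the only measured single-point change, a step that the two limits leave unreadable from compound 1 to compound 3, cannot be sized, as both ends sit at limits. Two of the three values rest at the limit of > 100000 nM in this assay, at which 2 of the 3 values shown sit, and the third at the limit of > 320000 nM in this assay, at which 1 of the 3 values shown sits.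

Compound 4 `COCCOCn1c(N)c(C#N)c2c(N)ncnc21` has not yet been measured in this assay. It differs from compound 1 by amino in place of bromo on an aromatic carbon. Within the data shown here, no measured step covers this change directly. Compound 2 also carries an amino group on its core, and its value is a limit, so an amino group at that position has not yet produced a measurable inhibitor within these compounds.

The step that the limit leaves unreadable from compound 1 to compound 4 is therefore expected to remain unreadable, with compound 4 most likely returning a limit as well. Compound 4 is estimated at 150000 nM, within a range from 30000 nM to 1000000 nM.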

Compound 4, half-maximal inhibitory concentration: 210000 nM
Compound 4: middle estimate off by 1.4-fold (0.15 log units), on the low side; low and high end bracket the measured number.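

In this assay compound 4 gives a number, 210000 nM. Compound 1 remains at > 100000 nM, which is a limit and not a number, so the step from bromo to amino between compound 1 and compound 4 cannot be read. The compounds shown leave open whether either change, on the chain or on the aromatic carbon, alters inhibition.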